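The source may report more compounds than this note shows. Statements on the series, on what has been measured and on what is new or still open speak of the compounds shown alone.

Measured compounds in a functional assay on A549 cells (Homo sapiens) for cytotoxicity, read by MTT assay, with a stated time of 48 h; a higher number here means a weaker inhibitor, a lower number a stronger inhibitor:
compound 1 `CCOC(=O)[C@@]1(C(=O)NCc2ccc(C)cc2)C[C@@H]1c1cc(OC)c(OC)c(OC)c1`: > 100000 nM, a limit of the assay
compound 2 `CCOC(=O)[C@@]1(C(=O)Nc2ccccc2)C[C@@H]1c1cc(OC)c(OC)c(OC)c1`: > 100000 nM, a limit of the assay
compound 3 `CCOC(=O)[C@@]1(C(=O)Nc2ccccc2Cl)C[C@@H]1c1cc(OC)c(OC)c(OC)c1`: 29000 nM

Compound 1 sits at the limit of > 100000 nM in this assay, at which 2 of the 3 values shown sit, so only a limit is known for it. The readable steps, an at least 3.4-fold lower number from compound 1 to compound 3 (0.53 log units; beyond the scatter) and an at least 3.4-fold lower number from compound 2 to compound 3 (0.53 log units; beyond the scatter), each change the group on the amide-type nitrogen; the step that the two limits leave unreadable from compound 1 to compound 2 is unreadable between two limits. Compound 4 `CCOC(=O)[C@]1(C(=O)NCc2ccc(C)cc2)C[C@@H]1c1cc(OC)c(OC)c(OC)c1` differs from compound 1 by the two compounds have the same atoms and bonds and differ only in configuration as drawn: 1 of 2 stereo elements differ; a stereocentre at a saturated ring carbon is drawn S in compound 1 and R in compound 4. For the measured compounds named here, no measured step changes configuration, so none bears on this change, and no step beyond the scatter is expected in this assay. Compound 4 is therefore expected to stay near its limit, with a number no higher from compound 1 to compound 4 (the limit leaves the size open) as the estimated step. Compound 4 is estimated at 100000 nM, in the range 30000 nM to 300000 nM.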

Compound 4, half-maximal inhibitory concentration: 34900 nM
Beside the measured number, compound 4's estimate is 2.9-fold (0.46 log units) above it, within the range that was stated.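

Configuration at this saturated ring carbon proves readable in this assay, where the earlier steps changed only the group on the amide-type nitrogen: the inversion gives an at least 2.8-fold lower number from compound 1 to compound 4 (0.45 log units; beyond the scatter). The step can be put down to this stereocentre alone, because of the following: the fact that compounds 1 and 4 differ only in the configuration as drawn. Going by these compounds, its full size stays open, since only a limit is known for compound 1: the limit of > 100000 nM in this assay, at which 2 of the 4 values shown sit.

On these data alone, whether the same inversion lowers the number with phenyl or 2-chlorophenyl on the amide-type nitrogen remains open. So do the effect of the second stereocentre and of a carboxylic acid in place of the ethyl ester.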